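The source may hold more compounds than are shown below. What is called first, only, known or untested is meant among the compounds shown, and "the series" means these compounds.

Measured compounds:

Compound 1, `N#Cc1ccc(S(=O)(=O)N2CCC(O)(COc3ccc(C#N)c(F)c3)CC2)c(C#N)c1`: 50.5 nM
Compound 2, `N#Cc1ccc(OCC2(O)CN(S(=O)(=O)c3ccc(Cl)cc3C#N)C2)cc1F`: 3.4 nM
Compound 3, `N#Cc1ccc(OCC2(O)CN(S(=O)(=O)c3ccc(Cl)cc3C#N)C2)cc1Cl`: 3.6 nM

In an assay on CHO-K1 cells for antagonist activity at transient receptor potential cation channel subfamily V member 4 (Homo sapiens), read by FLIPR and calcium flux, with a stated time of 5 min (on this read-out lower numbers stand for stronger inhibition and higher numbers for weaker inhibition), compound 3 stands second highest of the three numbers, next to compound 2, from which it differs only by chloro in place of fluoro on an aromatic carbon; that step, a 1.1-fold higher number from compound 2 to compound 3 (0.02 log units; within the scatter), lies within the scatter. Compound 1, which shares neither the core nor the sulfonyl aryl group of compound 3, gives the highest number of the three, well beyond the scatter from compound 3.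

Compound 4, `N#Cc1ccc(S(=O)(=O)N2CC(O)(COc3ccc(C#N)c(Cl)c3)C2)c(Cl)c1`, keeps the core and the phenoxy group of compound 3 and changes only the aryl group on the sulfonyl sulfur: 2-chloro-4-cyanophenyl in place of 4-chloro-2-cyanophenyl on a sulfonyl sulfur. Among the measured compounds shown here, no measured step bears on this change; the one step available, from compound 2 to compound 3, concerns a different part of the molecule, and compound 1 differs from compound 3 in two places at once. The expectation for compound 4 therefore rests on little, and a wide range is estimated, with the number expected to move by a 4.2-fold higher number from compound 3 to compound 4 (0.62 log units; beyond the scatter) in this assay. Compound 4 is estimated at 15 nM, between 3 nM and 80 nM.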

Compound 4, half-maximal inhibitory concentration: 4 nM
Compound 4: the middle estimate sits 3.8-fold (0.57 log units) above what was measured, and the stated range covers the measured number.
By their numbers in this assay, from the lowest: compounds 2, 3 and 4 (each within the scatter of the next); then compound 1.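

In this assay, moving from 4-chloro-2-cyanophenyl to 2-chloro-4-cyanophenyl on a sulfonyl sulfur gives a 1.1-fold higher number from compound 3 to compound 4 (0.05 log units; within the scatter), with the core and the phenoxy group held fixed. Among the compounds shown here, the earlier one-place step concerned a different part of the molecule, so this is the first direct reading at the sulfonyl aryl group: with the same atoms joined differently, the number stays within the scatter. Nothing measured here speaks to the reason for this result.

The compounds shown leave open what happens at this position when the nitrile is replaced by a carboxylic acid or the chloro by an amine. They also leave open whether the same exchange would give a similar step on the core of compound 1.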